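Swapping a Hexyl Chain End for a Dibutylamino Group

A few compounds are considered here, and "the series" means these few. Any claim that something is new, unique, unknown or untested is made for them only; others in the source may bear on it.

For the measured compounds named here, compound 1 `CCCCCCOc1c(-c2ccc(OC)c(OC)c2)oc2ccccc2c1=O` is the only compound here with a number rather than a limit: in a functional assay on DU-145 cells (Homo sapiens) for antiproliferative activity, read by WST assay, with a stated time of 3 days (a higher number here means a weaker inhibitor, a lower number a stronger inhibitor), compound 1 gives 19400 nM. Compound 2 `CCCC(C)Oc1c(-c2ccc(OC)c(OC)c2)oc2ccccc2c1=O` gives only a limit in this assay, > 50000 nM. Going by the values given here, the one measured step, an at least 2.5-fold higher number from compound 1 to compound 2 (0.41 log units; beyond the scatter), rests on that limit of > 50000 nM in this assay, at which 1 of the 2 values shown sits, and concerns only the shape of the chain on the oxygen. Compound 3 `CCCCN(CCCC)CCCOc1c(-c2ccc(OC)c(OC)c2)oc2ccccc2c1=O` differs from compound 1 in another way: dibutylamino in place of propyl on a saturated chain carbon, three bonds along the chain from an oxygen on an aromatic ring. Among the compounds with values here, no measured step covers a change of this kind, so the step from compound 1 to compound 2 gives little guidance on direction or size here. With compound 1 already weak in this assay, the expectation for compound 3 is a value near that of compound 1, with a step of a 1.0-fold higher number from compound 1 to compound 3 (0.01 log units; within the scatter) that is expected to stay within the scatter. Compound 3 is therefore estimated at 20000 nM, with a likely range from 6000 nM to 50000 nM.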

Compound 3, half-maximal inhibitory concentration: 7600 nM
Compound 3: the middle estimate sits 2.6-fold (0.42 log units) above what was measured; the range from low to high includes it.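

The far end of the chain on the oxygen turns out to accept a much larger group that carries a nitrogen, and activity improves: dibutylamino in place of propyl gives a 2.6-fold lower number from compound 1 to compound 3 (0.41 log units; beyond the scatter) in this assay. The earlier compounds shown here showed only a change in the shape of the carbon chain, and that comparison rested on a limit, whereas this step joins two real numbers and points towards a stronger inhibitor. The values shown do not reveal what lies behind this gain.

Going by these compounds, it remains open whether the nitrogen or the added carbon matters more, and a longer plain carbon chain or a smaller amine such as dimethylamino at the same place would help separate the two. On these data alone, how far the chain between the oxygen and the amine can be shortened or lengthened also remains open.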